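A few compounds are considered here, and "the series" means these few. Any claim that something is new, unique, unknown or untested is made for them only; others in the source may bear on it.

Working notes on the series. In a functional assay on OVCAR-5 cells (Homo sapiens) for cytotoxicity, read by sulforhodamine B assay, with a stated time of 48 h (on this read-out higher numbers stand for weaker inhibition of growth and lower numbers for stronger inhibition of growth), compound 2 `ClCc1ccccc1Cn1cnc2ncnc(Cl)c21` gives 2810 nM, the second highest of the three numbers in hand; compound 3 `ClCc1cccc(Cn2cnc3nc(Cl)nc(Cl)c32)c1` gives 1690 nM, a gap from compound 2 that lies within the scatter, while compound 1 `ClCc1cccc(Cn2cnc3c(Cl)nc(Cl)nc32)c1` gives 6450 nM, a gap beyond it. Compound 4 `ClCc1ccccc1Cn1cnc2nc(Cl)nc(Cl)c21` has not been measured. It differs from compound 2 in one place: chloro in place of hydrogen on an aromatic carbon. Among the compounds with values here, no measured pair isolates this change, so the step from compound 2 to compound 4 in this assay cannot be read off directly; a small step toward lower numbers, or none beyond the scatter, is expected, given that compound 3 carries two chloro groups on the same core and gives 1690 nM. Compound 4 is estimated at 2000 nM, with a range of 700 nM to 6000 nM, which means an expected step of a 1.4-fold lower number from compound 2 to compound 4 (0.15 log units; within the scatter).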

Compound 4, concentration for 50% growth inhibition: 2690 nM
Beside the measured number, compound 4's estimate is 1.3-fold (0.13 log units) below it; the measured number falls inside the stated range.
By their numbers in this assay, from the lowest: compounds 3, 4 and 2 (each within the scatter of the next); then compound 1.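

In this assay, within the data shown here, the one matched pair for this change gives a 1.0-fold lower number from compound 2 to compound 4 (0.02 log units; within the scatter), so chloro in place of hydrogen on the aromatic carbon between two ring nitrogen atoms moves the number no further than the scatter. Among these compounds, this position therefore accepts one chlorine atom without a measurable step, something the earlier compounds could not show. Nothing at hand explains why the step is so small. Open, on these data alone, is whether an amine, a methoxy group or a longer chain on this same carbon would leave the number equally unmoved. Also open, as far as these compounds go, is whether the same chloro step stays this small with the chloromethyl group placed as in compound 3.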